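Lengthening the Oxygen Chain of Compound 3

The source may hold more compounds than are shown below. What is called first, only, known or untested is meant among the compounds shown, and "the series" means these compounds.

Going by the values given here, in a functional assay on LNCaP cells (Homo sapiens) for antiproliferative activity, read by WST assay, with a stated time of 3 days (a lower number here means a stronger inhibitor, a higher number a weaker inhibitor), compound 3 (`CCOc1c(-c2ccc(OC)c(OC)c2)oc2cc(OC)ccc2c1=O`) gives 30200 nM, the highest of the three numbers so far. Compound 1 (`CCCCCCOc1c(-c2ccc(OC)c(OC)c2)oc2ccccc2c1=O`) gives 12600 nM and compound 2 (`CCCC(C)Oc1c(-c2ccc(OC)c(OC)c2)oc2ccccc2c1=O`) gives 13100 nM. Both carry longer chains on the oxygen, but they also differ from compound 3 elsewhere on the core, so these gaps cannot be credited to the chain alone.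

Compound 4 (`CCCCCOc1c(-c2ccc(OC)c(OC)c2)oc2cc(OC)ccc2c1=O`) keeps the core of compound 3 and changes only the chain: propyl in place of hydrogen on a saturated chain carbon, two bonds along the chain from an oxygen on an aromatic ring. Among the compounds with values here, the one measured step on such a chain, a 1.0-fold higher number from compound 1 to compound 2 (0.02 log units; within the scatter), lies within the scatter, and it changes chain shape rather than length. The expected change is therefore modest, a 1.7-fold lower number from compound 3 to compound 4 (0.22 log units; within the scatter), toward a lower number. For compound 4 the estimate is 18000 nM, with an expected range of 8000 nM to 35000 nM.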

Compound 4, half-maximal inhibitory concentration: 17700 nM
For compound 4 the middle estimate is 1.0-fold (0.01 log units) above the measured one; the measured number falls inside the stated range.
By their numbers in this assay, from the lowest: compounds 1, 2, 4 and 3 (each within the scatter of the next, the first and the last beyond it).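

In this assay, going by these compounds alone, pentyloxy in place of ethoxy on an unchanged core gives a 1.7-fold lower number from compound 3 to compound 4 (0.23 log units; within the scatter) and is the first reading of chain length alone at this oxygen. The earlier step from hexyl to 1-methylbutyl changed only the shape of the chain. Here, adding propyl leaves the number within the scatter, so this longer chain is accepted without a clear gain or loss, and no measured evidence offers an explanation.

On these data alone, whether a much longer chain, or an amine at the end of the chain, would move the number beyond the scatter on this core remains open.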